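Trading an eight-atom arm for a six-atom arm

A few compounds are considered here, and "the series" means these few. Any claim that something is new, unique, unknown or untested is made for them only; others in the source may bear on it.

Three measured compounds share one core and differ only in the arm attached through an amine nitrogen. In a functional assay on the whole organism with Rattus norvegicus as the target, at a dose of 100 mg/kg (on this read-out lower numbers stand for less inhibition and higher numbers for more inhibition at the one dose given (going by the name of the read-out)), compound 2 `O=c1ccc(-c2ccccc2)nn1CCCCNC(=S)Nc1ccccc1` gives 38.4%, compound 3 `CCC/N=C(/NC#N)NCCCCn1nc(-c2ccccc2)ccc1=O` gives 26.3%, and compound 1 `O=c1ccc(-c2ccccc2)nn1CCCCNC(=S)NCc1ccccc1` gives 5.4%. Compound 3 therefore stands second highest of the three. Compound 4 `C=CCNC(=S)NCCCCn1nc(-c2ccccc2)ccc1=O` carries a group of 6 heavy atoms (4 carbon, 1 nitrogen, 1 sulfur; no ring) in place of a group of 8 heavy atoms (5 carbon, 3 nitrogen; no ring), on an amine nitrogen. For the measured compounds named here, two steps bear on this change. The step of a number 12.1 percentage points lower from compound 2 to compound 3 (beyond the scatter) shows the eight-atom group sitting below a phenyl-bearing thiourea. The step of a number 33 percentage points higher from compound 1 to compound 2 (beyond the scatter) shows how much a benzyl thiourea, with a chain carbon on the nitrogen as in compound 4, lies below the phenyl one. Compound 4 is expected to follow compound 1 downward, with a step of a number 14.3 percentage points lower from compound 3 to compound 4 (beyond the scatter). Compound 4 is estimated at 12%, within 0% to 28%.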

Compound 4, a percentage reported as inhibition, in the whole organism at one dose (the size of the read-out at that dose, not a potency): 27.1%
Compound 4: middle estimate off by 15.1 percentage points, on the low side; the range from low to high includes it.
By their numbers in this assay, from the lowest: compound 1; then compounds 3 and 4 (each within the scatter of the next); then compound 2.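

The allyl thiourea compound 4 does not fall with the benzyl one in this assay, with a number 21.7 percentage points higher from compound 1 to compound 4 (beyond the scatter), so a saturated chain carbon on the thiourea nitrogen does not by itself bring the number down. The group of 6 heavy atoms and the group of 8 heavy atoms cannot be told apart here, with a number 0.8 percentage points higher from compound 3 to compound 4 (within the scatter). Phenyl keeps its lead over allyl, with a number 11.3 percentage points lower from compound 2 to compound 4 (beyond the scatter).

Nothing available explains these differences. As far as these compounds go, whether a longer chain or an amine on that nitrogen would land nearer compound 2 or compound 1 remains open.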